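The source may report more compounds than this note shows. Statements on the series, on what has been measured and on what is new or still open speak of the compounds shown alone.

In an ADME assay on Raji cells (Homo sapiens) for cytotoxicity, with a stated time of 72 h (on this read-out higher numbers stand for an effect only at larger amounts of compound and lower numbers for an effect already at smaller amounts), compound 1, with the structure `COc1ccc(NC(=O)Nc2cc(C)nc3ccccc23)cc1F`, gives only a limit, > 25000 nM. Compound 2, with the structure `Cc1cc(NC(=O)Nc2cc(F)ccc2F)c2ccccc2n1`, likewise gives only a limit in this assay, > 25000 nM. Compound 3, with the structure `Cc1cc(NC(=O)Nc2ncccc2C)c2ccccc2n1`, also reaches only a limit in this assay, > 25000 nM. Compound 3 therefore stands at the limit of > 25000 nM in this assay, at which 3 of the 3 values shown sit, and on these numbers nothing sets it apart from compound 1 or compound 2. Compound 4 has the structure `Cc1cc(NC(=O)Nc2ccc(F)cc2)c2ccccc2n1`. It differs from compound 3 in one place: 4-fluorophenyl in place of 3-methylpyridin-2-yl on an amide-type nitrogen. Among the measured compounds shown here, no step between two measured compounds is available, so the effect of this change on cytotoxicity in this assay cannot be read from any measured pair. All three measured compounds sit at the same limit, and the replacement keeps the size of the group on the amide-type nitrogen unchanged. The expected step is a step that the limit leaves unreadable from compound 3 to compound 4, that is, none beyond the usual scatter. Compound 4 is accordingly expected to give about 30000 nM in this assay, within a range from 15000 nM to 60000 nM, and most likely again reported only as a limit.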

Compound 4, half-maximal effective concentration: > 25000 nM
Compound 4: no number, only a limit; the forecaster's own chance of this, stated with the estimate: 80%; the middle value is on the limit's open side.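

Among the compounds shown here, compound 3 and compound 4 both give only a limit, so no step between them can be read. The compounds shown leave open whether 4-fluorophenyl in place of 3-methylpyridin-2-yl changes cytotoxicity at all, and whether any compound differs from the others: the limit of > 25000 nM in this assay, at which 4 of the 4 values shown sit.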